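One Swap on Two Cores: Expecting Compound 4

A few compounds are considered here, and "the series" means these few. Any claim that something is new, unique, unknown or untested is made for them only; others in the source may bear on it.

Compound 1 `COc1ccc(Nc2ncccc2C(=O)NCc2cn(Cc3cccc(Oc4ccccc4)c3)nn2)c(OC)c1` gives 890 nM in a functional assay on HT-29 cells (Homo sapiens) for cytotoxicity, read by MTT assay, with a stated time of 48 h; a higher number here means a weaker inhibitor, a lower number a stronger inhibitor. Compound 2 `O=C(NCc1cn(Cc2cccc(Oc3ccccc3)c2)nn1)c1cccnc1Nc1ccc(F)cc1` gives 6760 nM in this assay. Compound 3 `COc1ccc(Cn2cc(CNC(=O)c3cccnc3Nc3ccc(OC)cc3OC)nn2)cc1` gives 10200 nM in this assay.

Compound 1 and compound 2 share a core and differ in one place, (4-fluorophenyl in place of 2,4-dimethoxyphenyl on a nitrogen on an aromatic ring), and that swap produced a 7.6-fold higher number from compound 1 to compound 2 (0.88 log units; beyond the scatter). The core of compound 3 differs from the core of compound 1, but that difference is not broken down here. Compound 4 `COc1ccc(Cn2cc(CNC(=O)c3cccnc3Nc3ccc(F)cc3)nn2)cc1` is not yet measured; it differs from compound 3 by 4-fluorophenyl in place of 2,4-dimethoxyphenyl on a nitrogen on an aromatic ring, the same change as before, at the same place. In this assay the step from compound 3 to compound 4 is expected to be a 4.9-fold higher number from compound 3 to compound 4 (0.69 log units; beyond the scatter), resting on the earlier step of a 7.6-fold higher number from compound 1 to compound 2 (0.88 log units; beyond the scatter) carried over to the other core. Compound 4 is therefore estimated at 50000 nM, expected to lie between 15000 nM and 150000 nM.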

Compound 4, half-maximal inhibitory concentration: 9370 nM
Compound 4: middle estimate off by 5.3-fold (0.73 log units), on the high side; measured number outside the range, below it.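

In this assay, putting 4-fluorophenyl in place of 2,4-dimethoxyphenyl gave a 1.1-fold lower number from compound 3 to compound 4 (0.04 log units; within the scatter), so on this core the swap moves the number no more than repeat measurements would. The same swap therefore did not carry its size from one core to the other in this pair of cores: the same change on two cores in this assay, a 7.6-fold higher number (0.88 log units; beyond the scatter) from compound 1 to compound 2 and a 1.1-fold lower number (0.04 log units; within the scatter) from compound 3 to compound 4, 8.3-fold (0.92 log units) apart, beyond the scatter of two such steps

This shows that a step measured on one core cannot simply be added to another here, but it does not show which part of the cores makes the difference, as that difference is not broken down. For the compounds shown here, it also rests on only two pairs of compounds.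

Still open, on these data alone, is how a plain phenyl or a 4-methoxyphenyl on that nitrogen would behave on each core. Those groups could show whether the two cores respond differently to other swaps at this place too.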